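This account rests on a few compounds, and the source may have more. Where it says the series, first, only, none or still open, it means among the compounds named here.

Measured compounds:
compound 1 `COC(=O)Cn1c(=O)c(C)cn([C@@H]2O[C@H](CO[Si](C)(C)C(C)(C)C)[C@@]3(OS(=O)(=O)C=C3N)[C@H]2O[Si](C)(C)C(C)(C)C)c1=O` with > 152000 nM
compound 2 `Cc1cn([C@@H]2O[C@H](CO[Si](C)(C)C(C)(C)C)[C@@]3(OS(=O)(=O)C=C3N)[C@H]2O[Si](C)(C)C(C)(C)C)c(=O)n(CC(=O)O)c1=O` with 152000 nM

Compound 2 is the only one of the two with an actual number in a functional assay on CCRF-CEM cells (Homo sapiens); a lower number here means that less compound is tolerated, a higher number that more compound is tolerated: compound 2 gives 152000 nM. For compound 1 the result is a limit of the assay and not a number: compound 1 gives > 152000 nM. Among the compounds with values here, the one measured step, a number no higher from compound 1 to compound 2 (the limit leaves the size open), therefore has no readable size; it says only that the number did not rise, which is all that the limit of > 152000 nM in this assay, at which 1 of the 2 values shown sits, can show.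

Compound 3 `Cc1cn([C@@H]2O[C@H](CO[Si](C)(C)C(C)(C)C)[C@@]3(OS(=O)(=O)C=C3N)[C@H]2O[Si](C)(C)C(C)(C)C)c(=O)n(C/C=C/CO)c1=O` differs from compound 2 in the change (3-hydroxyprop-1-en-1-yl in place of carboxy on a saturated chain carbon bound to an aromatic nitrogen). This is not the same kind of change as the measured one, so the measured step gives no direct guide to its size or direction. Because both known results sit at the limit described by the limit of > 152000 nM in this assay, at which 1 of the 2 values shown sits, compound 3 is expected to stay near the same place, and a further limit rather than a number is a real possibility. Compound 3 is therefore estimated at 152000 nM, with a range from 50000 nM to 300000 nM, which means an expected step of no change at the digits printed from compound 2 to compound 3 (within the scatter).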

Compound 3, half-maximal cytotoxic concentration: 4410 nM
The estimate for compound 3 lay 34-fold (1.54 log units) above the measured number; measured number outside the range, below it.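

This result shows that the substituent on the saturated chain carbon bound to an aromatic nitrogen can matter in this assay, which the earlier pair could not show: putting 3-hydroxyprop-1-en-1-yl in place of carboxy gives a 34-fold lower number from compound 2 to compound 3 (1.54 log units; beyond the scatter). Putting the same group in place of methoxycarbonyl gives an at least 34-fold lower number from compound 1 to compound 3 (1.53 log units; beyond the scatter). Compound 1 gives > 152000 nM, which is a limit of the assay and not a number, so the size of that second step is only a minimum: the limit of > 152000 nM in this assay, at which 1 of the 3 values shown sits.

The compounds shown do not tell whether the lower number goes with the terminal hydroxyl, the carbon-carbon double bond, the longer chain or the loss of the carboxy and methoxycarbonyl groups, as all of these change together in a single step. A saturated 4-hydroxybutyl chain, or a chain of the same length ending in an amine, would be the kind of group needed to pull these features apart at this place.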